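Replacing the oxanyl amine with a group carrying two four-membered rings

The compounds below may be only part of what the source reports. "The series", "measured", "known", "first", "only" and "open" are said of these compounds alone.

Compound 1 `CN(C)CCCCN(C[C@H]1Cc2ncccc2CN1)[C@H]1CCCc2cccnc21`: 2 nm/s
Compound 2 `CN(CCCCN(C[C@H]1Cc2ncccc2CN1)[C@H]1CCCc2cccnc21)C1CCOCC1`: 15 nm/s

In an ADME assay for permeability, using PAMPA, with a stated time of 4 h, at pH 5.5 (on this read-out higher numbers stand for higher permeability and lower numbers for lower permeability), only these two compounds have been measured so far. Compound 2 holds the higher number at 15 nm/s, and the gap to compound 1 lies beyond the scatter. The next compound, compound 3 `c1cnc2c(c1)CN[C@@H](CN(CCCCN(C1COC1)C1COC1)[C@H]1CCCc3cccnc31)C2`, has not yet been measured. It differs from compound 2 in one place: a group of 9 heavy atoms (6 carbon, 1 nitrogen, 2 oxygen; 2 four-membered non-aromatic rings with 1 hetero atom each) in place of a group of 8 heavy atoms (6 carbon, 1 nitrogen, 1 oxygen; one six-membered non-aromatic ring with 1 hetero atom), on a saturated chain carbon, four bonds along the chain from an amine nitrogen.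

For the measured compounds named here, only one measured step bears on this change, a 7.5-fold higher number from compound 1 to compound 2 (0.88 log units; beyond the scatter). There, oxan-4-yl stands in place of methyl on an amine nitrogen, at the same end of the molecule that changes now. That step is modest but clear. It is also only a loose guide, since neither measured compound carries a four-membered ring and one step cannot show a trend.

Going by a 7.5-fold higher number from compound 1 to compound 2 (0.88 log units; beyond the scatter), a modest rise rather than a fall is expected, estimated as a 2.0-fold higher number from compound 2 to compound 3 (0.30 log units; within the scatter). For compound 3 the expected value is 30 nm/s, with an estimated range of 8 nm/s to 110 nm/s.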

Compound 3, apparent permeability: 62 nm/s
For compound 3 the middle estimate is 2.1-fold (0.32 log units) below the measured one; low and high end bracket the measured number.
By their numbers in this assay, from the lowest: compound 1; then compound 2; then compound 3.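

In this assay, the group with 2 four-membered non-aromatic rings gives a 4.1-fold higher number from compound 2 to compound 3 (0.62 log units; beyond the scatter), so this position still responds when one ring-bearing group replaces another, even though the group changes only from 8 to 9 heavy atoms. The earlier compounds shown here showed only what happened when methyl gave way to oxan-4-yl; this result shows that the kind and number of rings on the amine nitrogen also go with a difference beyond the scatter. Measured against the smaller group of compound 1, the change amounts to a 31-fold higher number from compound 1 to compound 3 (1.49 log units; beyond the scatter), a large span at this single place, but nothing measured here explains the rise in either step.

Going by these compounds, the step from compound 2 to compound 3 alters ring size, ring number and the count of oxygen atoms at once, so the share of each stays open, and a methyl(oxetan-3-yl)amino group would help to separate them. Also open, on these data alone, is whether the higher number would hold for other groups at this place, such as a morpholine or an azetidine.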